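This account rests on a few compounds, and the source may have more. Where it says the series, first, only, none or still open, it means among the compounds named here.

Within the data shown here, compound 1 `COc1cc2c(Nc3ccc(C#N)cc3)ncnc2cc1OCCCN1CCC(CO)CC1` is the only member of this small set for which a functional assay on SH-SY5Y cells (Homo sapiens) for antiproliferative activity, read by MTT assay, with a stated time of 72 h (a lower number here means a stronger inhibitor, a higher number a weaker inhibitor), returns a number: in this assay compound 1 gives 21600 nM. Compound 2 `COc1cc2c(Nc3ccc(C#N)cc3)ncnc2cc1OCCCN1CCc2ccccc2C1` is reported in this assay only as a limit, > 100000 nM, so it sets no number of its own (the limit of > 100000 nM in this assay, at which 1 of the 2 values shown sits). Among the measured compounds shown here, the one measured step, an at least 4.6-fold higher number from compound 1 to compound 2 (0.66 log units; beyond the scatter), therefore says only that a large change at this position can weaken inhibition by at least a modest amount.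

Compound 3 `CCN1CCN(CCCOc2cc3ncnc(Nc4ccc(C#N)cc4)c3cc2OC)CC1` differs from compound 1 in the same place: 4-ethylpiperazin-1-yl in place of 4-(hydroxymethyl)piperidin-1-yl on a saturated chain carbon, three bonds along the chain from an oxygen on an aromatic ring. For the measured compounds named here, no measured step covers this particular exchange, and the step from compound 1 to compound 2 describes a quite different group entering, so it bears on compound 3 only loosely. He therefore expects no movement beyond the scatter, with a lean toward slight weakening given the limit seen for compound 2. His estimate for compound 3 in this assay is 25000 nM, between 8000 nM and 80000 nM, which corresponds to an expected step of a 1.2-fold higher number from compound 1 to compound 3 (0.06 log units; within the scatter).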

Compound 3, half-maximal inhibitory concentration: 5440 nM
Beside the measured number, compound 3's estimate is 4.6-fold (0.66 log units) above it; measured number below the stated range.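

The exchange of 4-(hydroxymethyl)piperidin-1-yl for 4-ethylpiperazin-1-yl shows that a change at this place on the saturated chain can also strengthen inhibition in this assay, giving a 4.0-fold lower number from compound 1 to compound 3 (0.60 log units; beyond the scatter), even though both groups are six-membered non-aromatic rings of 8 heavy atoms. The choice of ring group therefore matters in either direction, and the two groups that enter in place of 4-(hydroxymethyl)piperidin-1-yl stand far apart, with an at least 18-fold lower number from compound 2 to compound 3 (1.26 log units; beyond the scatter). The size of that second step is not an exact one, as compound 2 is reported only as a limit: the limit of > 100000 nM in this assay, at which 1 of the 3 values shown sits.

The exchange alters the second ring nitrogen, the ethyl group and the hydroxymethyl group at once, so the compounds shown leave open which of these changes goes with the stronger inhibition. An unsubstituted piperazin-1-yl, a 4-methylpiperazin-1-yl or a morpholin-4-yl group on the same propyl chain would help separate them, and a butyl chain carrying 4-ethylpiperazin-1-yl would show whether the step depends on the length of the chain.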